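A few compounds are considered here, and "the series" means these few. Any claim that something is new, unique, unknown or untested is made for them only; others in the source may bear on it.

Compound 1 `COc1ccc(/C=C\c2cc(OC)c(OC)c(OC)c2)cc1OCc1ccc(C=O)cc1` gives 4200 nM
Compound 2 `COc1ccc(/C=C\c2cc(OC)c(OC)c(OC)c2)cc1OCc1ccc(CN2CC[C@H](C(=O)O)C2)cc1` gives 7000 nM
Compound 3 `COc1ccc(/C=C\c2cc(OC)c(OC)c(OC)c2)cc1OCc1ccc(CN2CCCCC2C(=O)NCCN)cc1` gives 4600 nM

In a functional assay on B16-F10 cells (Mus musculus) for antiproliferative activity, read by CCK-8 assay, with a stated time of 48 h (a lower number here means a stronger inhibitor, a higher number a weaker inhibitor), compound 3 stands within the scatter of both other compounds, so these three numbers show no real order.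

Compound 4 `COc1ccc(/C=C\c2cc(OC)c(OC)c(OC)c2)cc1OCc1ccc(CN[C@H](C(=O)O)[C@@H](C)O)cc1` is not yet measured. It carries (1-carboxy-2-hydroxypropyl)amino in place of 2-((2-aminoethyl)carbamoyl)piperidin-1-yl on a saturated chain carbon bound to an aromatic carbon, and the change counts out as (1-carboxy-2-hydroxypropyl)amino in place of 2-((2-aminoethyl)carbamoyl)piperidin-1-yl on a saturated chain carbon bound to an aromatic carbon in full.

Two measured steps also exchanged groups in this part of the molecule. The first is a 1.7-fold higher number from compound 1 to compound 2 (0.22 log units; within the scatter) and the second is a 1.5-fold lower number from compound 2 to compound 3 (0.18 log units; within the scatter) in size. Neither goes beyond the scatter, although the groups involved were quite different. Compound 2 also holds a carboxy group and gives 7000 nM in the same range as the others.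

No step beyond the scatter is therefore expected in this assay and the estimated change is a 1.3-fold higher number from compound 3 to compound 4 (0.12 log units; within the scatter) at most a small one. For compound 4 the expected value is 6000 nM with an estimated range from 2800 nM to 13000 nM around it.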

Compound 4, half-maximal inhibitory concentration: 5400 nM
The estimate for compound 4 lay 1.1-fold (0.05 log units) above the measured number; the measured number falls inside the stated range.
By their numbers in this assay, from the lowest: compounds 1, 3, 4 and 2 (each within the scatter of the next).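

In this assay, the step of a 1.2-fold higher number from compound 3 to compound 4 (0.07 log units; within the scatter) replaces 2-((2-aminoethyl)carbamoyl)piperidin-1-yl with (1-carboxy-2-hydroxypropyl)amino on a saturated chain carbon bound to an aromatic carbon, so here a group with no ring takes the place of one with a six-membered ring and the number stays within the scatter. The other two comparisons, a 1.3-fold lower number from compound 2 to compound 4 (0.11 log units; within the scatter) and a 1.3-fold higher number from compound 1 to compound 4 (0.11 log units; within the scatter), are also within the scatter, which places this open-chain group in the same range as the formyl and both ring-bearing groups. Nothing available explains why these numbers stay so close.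

From the compounds shown here alone, whether any group here can move the number beyond the scatter remains open, for example a sulfonamide or a guanidine on a longer chain. Also open, going by these compounds, is whether the opposite arrangement at the two defined stereocentres of compound 4 would read differently.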